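The compounds below may be only part of what the source reports. "The series", "measured", "known", "first", "only" and "open" are said of these compounds alone.

The study concerns three measured compounds and a fourth whose result is still to come. Compound 1 `COc1ccccc1C(=O)/C=C/c1ccc2c(c1)B(O)OC2` gives 3100 nM in a functional assay on MDA-MB-231 cells (Homo sapiens) for cytotoxicity, read by MTT assay, with a stated time of 48 h; on this read-out higher numbers stand for weaker inhibition and lower numbers for stronger inhibition. Compound 2 `COc1cccc(C(=O)/C=C/c2ccc3c(c2)B(O)OC3)c1` shares the same atoms with compound 1 but joined differently; in this assay compound 2 gives 2100 nM; the difference between the two cores is not broken down here, and the two values lie within the scatter of each other. Compound 3 `COCOc1ccccc1C(=O)/C=C/c1ccc2c(c1)B(O)OC2` gives 10200 nM in this assay. Compound 3 differs from compound 1 by methoxy in place of hydrogen on a saturated chain carbon bound to an oxygen on an aromatic ring, and that change produced a 3.3-fold higher number from compound 1 to compound 3 (0.52 log units; beyond the scatter), a modest step beyond the scatter.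

Compound 4 `COCOc1cccc(C(=O)/C=C/c2ccc3c(c2)B(O)OC3)c1` has not yet been measured. It differs from compound 2 by methoxy in place of hydrogen on a saturated chain carbon bound to an oxygen on an aromatic ring, the same change, at the same place, as that from compound 1 to compound 3. The expected step is a 3.3-fold higher number from compound 2 to compound 4 (0.52 log units; beyond the scatter), resting on compound 1 and the step of a 3.3-fold higher number from compound 1 to compound 3 (0.52 log units; beyond the scatter) in this assay. Compound 4 is therefore estimated to give about 7000 nM in this assay, expected to fall between 3000 nM and 16000 nM.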

Compound 4, half-maximal inhibitory concentration: 4500 nM
Compound 4: the middle estimate sits 1.6-fold (0.19 log units) above what was measured, within the range that was stated.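

In this assay, the same methoxy change on the second core gives a 2.1-fold higher number from compound 2 to compound 4 (0.33 log units; beyond the scatter), in the same direction as on the first. Set beside the earlier step, the two sizes do not differ beyond what repeated measurement would allow: the same change on two cores in this assay, a 3.3-fold higher number (0.52 log units; beyond the scatter) from compound 1 to compound 3 and a 2.1-fold higher number (0.33 log units; beyond the scatter) from compound 2 to compound 4, 1.5-fold (0.19 log units) apart, within the scatter of two such steps On these two pairs, the change therefore carried over from the core of compound 1 to the core of compound 2, but this does not show that it would carry to any other core, and it does not explain why the number rises on either one.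

The compounds shown leave open what other groups would do at this place, on a saturated chain carbon bound to an oxygen on an aromatic ring, such as an amine, a carboxylic acid or a longer chain than methoxy. Within the data shown here, they also leave open whether the two cores would keep step with each other once such groups replace methoxy, since only this single change is available for comparison.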